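Swapping an aryl for a chloroalkyl chain on the alkyne

This account rests on a few compounds, and the source may have more. Where it says the series, first, only, none or still open, it means among the compounds named here.

Measured compounds:
- compound 1 `CC(=O)OCC(CCn1cc(C#CCc2ccccc2)c(=O)n(C(=O)c2ccccc2)c1=O)COC(C)=O`: in a functional assay on SW-620 cells (Homo sapiens) for antiproliferative activity, read by MTT assay, with a stated time of 72 h (a higher number here means a weaker inhibitor, a lower number a stronger inhibitor), compound 1 gives 36400 nM
- compound 2 `CCCCCC#Cc1cn(CCC(COC(C)=O)COC(C)=O)c(=O)n(C(=O)c2ccccc2)c1=O`: compound 2 gives 40700 nM
- compound 3 `O=c1[nH]c(=O)n(CCC(CO)CO)cc1C#Cc1cc(F)cc(F)c1`: compound 3 reaches only the limit of > 100000 nM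

Compound 3 is thus not a number but a limit of the assay, the only one among the three shown that sits at the limit of > 100000 nM in this assay, at which 1 of the 3 values shown sits. Compounds 1 and 2 carry the same acetylated diol chain and benzoyl group on the shared core and differ only at the alkyne terminus; that change gave a 1.1-fold higher number from compound 1 to compound 2 (0.05 log units; within the scatter). Within the data shown here, compound 3 lacks both acetyl groups and the benzoyl group, so no single step links it to either of them.

Compound 4 `O=c1[nH]c(=O)n(CCC(CO)CO)cc1C#CCCCCl` keeps the free diol and the unsubstituted core of compound 3 and differs only at the alkyne: 3-chloropropyl in place of 3,5-difluorophenyl on a triple-bonded carbon. Among the measured compounds shown here, the one measured step that bears on such a change, from compound 1 to compound 2, was within the scatter. On that basis no shift beyond the scatter is expected, and compound 4 is expected to remain at or near the limit, the estimated step being a step that the limit leaves unreadable from compound 3 to compound 4. Compound 4 is therefore estimated at 150000 nM, between 50000 nM and 500000 nM.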

Compound 4, half-maximal inhibitory concentration: > 100000 nM
Compound 4: no number, only a limit; the forecaster's own chance of this, stated with the estimate: 70%; the middle value does not contradict the limit.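

In this assay compound 4 gives > 100000 nM, which is a limit and not a number. Compound 3 also stands at a limit, so no step can be read between compound 3 and compound 4. The compounds shown leave open how the 3,5-difluorophenyl and 3-chloropropyl groups compare, and how either of these two compounds relates to compound 1 and compound 2.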